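The compounds below may be only part of what the source reports. "The series", "measured", "known", "first", "only" and "open" are said of these compounds alone.

In a functional assay on CHO-K1 cells for agonist activity at G-protein coupled receptor 6 (Homo sapiens), read by TR-FRET and cAMP accumulation, with a stated time of 20 h (on this read-out lower numbers stand for an effect already at smaller amounts and higher numbers for an effect only at larger amounts of compound), compound 1 `CN(C)C(=O)c1ccc2nc(NC3CC3)c(N3CCN(Cc4cc(Cl)ccc4Cl)CC3)nc2c1` gives 90 nM. Compound 2 `CC(C)Nc1nc2c(nc1N1CCC(Oc3ccc(F)cc3F)CC1)C=CNC2` gives 100000 nM in this assay, the highest of the two numbers and far from compound 1. Compound 3 `CC(C)Nc1nc2c(nc1N1CCC(Oc3ccc(F)cc3F)CC1)C=CN(S(C)(=O)=O)C2` follows from compound 2 by methylsulfonyl in place of hydrogen on an amine nitrogen in a ring. Going by the values given here, no measured pair shows this change, so the size of the step in this assay is unknown; with compound 2 already at 100000 nM, he expects a step of a 1.3-fold lower number from compound 2 to compound 3 (0.10 log units; within the scatter), that is, little or no movement beyond the scatter. For compound 3 he estimates 80000 nM, within 20000 nM to 150000 nM.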

Compound 3, half-maximal effective concentration: 65000 nM
For compound 3 the middle estimate is 1.2-fold (0.09 log units) above the measured one; measured number inside the range.
By their numbers in this assay, from the lowest: compound 1; then compounds 3 and 2 (each within the scatter of the next).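

In this assay the nitrogen of the six-membered non-aromatic ring now has a measured change: methylsulfonyl in place of hydrogen gives a 1.5-fold lower number from compound 2 to compound 3 (0.19 log units; within the scatter) and so stays within the scatter. On this read-out, compound 2 and compound 3 cannot be told apart, even though the new group adds four heavy atoms at this position. Nothing given here accounts for this result.

As far as these compounds go, it remains open whether an acetyl group, a longer alkyl chain or an aminoethyl chain on this nitrogen would give a step beyond the scatter. From the compounds shown here alone, it also remains open whether methylsulfonyl would give a similar step on another core.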